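Pentyl-amine ether series: swapping the benzylic aryl group

The source may hold more compounds than are shown below. What is called first, only, known or untested is meant among the compounds shown, and "the series" means these compounds.

Measured so far in a functional assay on SK-OV-3 cells (Homo sapiens) for inhibition, read by CCK-8 assay, with a stated time of 70 h; a higher number here means a weaker inhibitor, a lower number a stronger inhibitor:
compound 1 `Nc1ccc(COc2ccc(OCCOCCNC3CCCC3)cc2)cc1` gives 31700 nM
compound 2 `c1ccc(COc2ccc(COc3ccc(OCCOCCNC4CCCC4)cc3)cc2)cc1` gives 10000 nM
compound 3 `c1ccc(COc2ccccc2OCCOCCNC2CCCC2)cc1` gives 40700 nM

Compound 1 and compound 3 give numbers that lie within the usual scatter of each other in this assay, so no order between them is read. Among the compounds with values here, compound 2 sits apart from both: the one step measured from compound 1, a 3.2-fold lower number from compound 1 to compound 2 (0.50 log units; beyond the scatter), puts benzyloxy in place of amino on the aromatic carbon and gives a modest but real lowering of the number.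

Compound 4 `COC(=O)c1ccccc1COc1ccc(OCCOCCNC2CCCC2)cc1` is not yet measured. It differs from compound 1 in one place: 2-(methoxycarbonyl)phenyl in place of 4-aminophenyl on a saturated chain carbon bound to an oxygen on an aromatic ring. The aryl group on the benzylic carbon is exchanged as a whole, so the amino donor leaves and an ester enters in its place.

Within the data shown here, the only step that bears on this is the one from compound 1 to compound 2, where removing the amino and adding a larger aryl ether gave a modest lowering. Compound 4 also loses the amino and gains a substituted aryl, but the group that enters is not the same, so the step to compound 4 is expected to be at most modest, more likely to the lower side and possibly within the scatter. Compound 4 is therefore expected at 20000 nM, with a range from 6000 nM to 60000 nM, which means an expected step of a 1.6-fold lower number from compound 1 to compound 4 (0.20 log units; within the scatter).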

Compound 4, half-maximal inhibitory concentration: > 100000 nM
Compound 4 was reported as a limit; the forecaster's own chance of this, stated with the estimate: 10%; middle value at least 5.0-fold (0.69 log units) away from the limit.
By their numbers in this assay, from the lowest: compound 2; then compounds 1 and 3 (each within the scatter of the next). At a limit, above all of these: compound 4.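

In this assay compound 4 gives > 100000 nM, which is a limit of the assay and not a number. The aryl group on the saturated chain carbon bound to an oxygen on an aromatic ring does not tolerate every exchange: 2-(methoxycarbonyl)phenyl in place of 4-aminophenyl gives an at least 3.1-fold higher number from compound 1 to compound 4 (0.49 log units; beyond the scatter), the opposite direction to the earlier step, a 3.2-fold lower number from compound 1 to compound 2 (0.50 log units; beyond the scatter). Both steps remove the amino group, so its loss alone does not set the direction of the change, and the size of the rise stays open-ended: the limit of > 100000 nM in this assay, at which 1 of the 4 values shown sits.

Compound 4 changes the substituent and its place on the ring together, so the compounds shown do not separate the effect of the ester from the effect of where it sits. A carboxylic acid or a primary amide in place of the methyl ester, or an unsubstituted phenyl on the same carbon, would show whether the higher number goes with the ester itself or with any substituent at that place.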